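The compounds below may be only part of what the source reports. "The series", "measured", "known", "first", "only" and "open" are said of these compounds alone.

Compound 1 `CCCCc1nc(N)c2nc(O)n(Cc3ccccc3)c2n1` gives 0.03 uM in a functional assay (spleen, spleen) for activation, with Mus musculus as the target; on this read-out lower numbers stand for an effect already at smaller amounts and higher numbers for an effect only at larger amounts of compound. Compound 2 `CCCCSc1nc(N)c2nc(O)n(Cc3ccccc3)c2n1` gives 0.01 uM. Compound 3 `CCNc1nc(N)c2nc(O)n(Cc3ccccc3)c2n1` gives 1 uM.

Compound 3 stands at the highest number of the three, with a 33-fold higher number from compound 1 to compound 3 (1.52 log units; beyond the scatter) and a 100-fold higher number from compound 2 to compound 3 (2.00 log units; beyond the scatter). Compound 4 `Nc1nc(S)nc2c1nc(O)n2Cc1ccccc1` differs from compound 3 by sulfanyl in place of ethylamino on an aromatic carbon. Within the data shown here, the step that bears on this change is a 100-fold higher number from compound 2 to compound 3 (2.00 log units; beyond the scatter), where the compound carrying butylsulfanyl had the far lower number; compound 4 carries sulfur too, but without the butyl chain, and no measured step shows what the missing chain means. The pull of the sulfur-bearing step and the unknown loss of the chain leave an estimated change of no change at the digits printed from compound 3 to compound 4 (within the scatter), within the scatter. Compound 4 is therefore expected to give 1 uM, with a range from 0.1 uM to 10 uM.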

Compound 4, minimum effective concentration: 10 uM
Beside the measured number, compound 4's estimate is 10-fold (1.00 log units) below it; low and high end bracket the measured number.
By their numbers in this assay, from the lowest: compound 2; then compound 1; then compound 3; then compound 4.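

In this assay the loss of the butyl from the sulfur gives a 1000-fold higher number from compound 2 to compound 4 (3.00 log units; beyond the scatter) and shows that sulfur on this aromatic carbon does not alone bring the low number of compound 2. The bare sulfanyl also needs more compound than the other groups here, with a 10-fold higher number from compound 3 to compound 4 (1.00 log units; beyond the scatter) against ethylamino and a 330-fold higher number from compound 1 to compound 4 (2.52 log units; beyond the scatter) against butyl. No evidence is available on what lies behind these steps.

As far as these compounds go, how the number follows chain length on the sulfur stays open, as between methylsulfanyl and hexylsulfanyl. A butylamino group at this position is also an open case.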